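A Methyl Added to the Sulfonyl Phenyl

The compounds below may be only part of what the source reports. "The series", "measured", "known", "first", "only" and "open" are said of these compounds alone.

Compound 1 `CS(=O)(=O)N1C(=O)COC12C=CC(=O)C=C2` and compound 2 `O=C1C=CC2(C=C1)OCC(=O)N2S(=O)(=O)c1ccccc1` share one core and differ only at the sulfonyl sulfur. In a functional assay on HepG2 cells (Homo sapiens) for inhibition, read by sulforhodamine B assay, with a stated time of 74 h (on this read-out lower numbers stand for stronger inhibition and higher numbers for weaker inhibition), compound 1 gives > 10000 nM, which is a limit of the assay and not a number. In this assay compound 2 gives > 10000 nM, again a limit. The step that the two limits leave unreadable from compound 1 to compound 2 cannot be read because the limit of > 10000 nM in this assay, at which 2 of the 2 values shown sit, holds both values. Among the compounds with values here, compound 2 therefore stands only at a limit, and the one other value shown sits at the same limit.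

Compound 3 `Cc1ccccc1S(=O)(=O)N1C(=O)COC12C=CC(=O)C=C2` differs from compound 2 by methyl in place of hydrogen on an aromatic carbon; cut one bond further out, the same difference reads phenyl to 2-methylphenyl. Within the data shown here, no measured step bears readably on this change, so no step beyond the scatter is expected in this assay. Compound 3 is expected to give 15000 nM, within 5000 nM to 50000 nM. The expected step that the limit leaves unreadable from compound 2 to compound 3 is thus estimated as essentially none, with a further limit the most likely outcome.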

Compound 3, half-maximal inhibitory concentration: 750 nM
Beside the measured number, compound 3's estimate is 20-fold (1.30 log units) above it; the whole stated range lies above it.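

In this assay, methyl in place of hydrogen on an aromatic carbon, ortho to a large group, gives an at least 13-fold lower number from compound 2 to compound 3 (1.12 log units; beyond the scatter), a readable step where the earlier pair gave none. Set against the methyl on the sulfonyl sulfur, the 2-methylphenyl group gives an at least 13-fold lower number from compound 1 to compound 3 (1.12 log units; beyond the scatter), so the group on the sulfonyl sulfur can change the read-out after all, provided it carries this added methyl. The full size of both steps stays open because each starts from a limit, not a number: the limit of > 10000 nM in this assay, at which 2 of the 3 values shown sit.

The compounds shown do not tell whether the methyl must stand at this place on the phenyl ring, or whether an amine or a methoxy group there would serve as well. Nor do they tell why the methyl produces this step, or whether a longer chain such as ethyl would carry it further.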